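The compounds below may be only part of what the source reports. "The series", "measured", "known", "first", "only" and "open" are said of these compounds alone.

Among the compounds with values here, of the three numbers in an assay on CHO cells for antagonist activity at transient receptor potential cation channel subfamily V member 1 (Homo sapiens), read by FLIPR and calcium flux (on this read-out lower numbers stand for stronger inhibition and higher numbers for weaker inhibition), the one for compound 2 `CCC1CCC(c2nc(C(F)(F)F)ccc2CNC(=O)[C@@H](C)c2ccc(NS(C)(=O)=O)c(F)c2)CC1` is the smallest at 0.2 nM; compound 3 `CCC1CCC(c2nc(C(F)(F)F)ccc2CNC(=O)C(C)c2ccc(NS(C)(=O)=O)c(F)c2)CC1` at 0.3 nM sits within the scatter of it, a 1.5-fold higher number from compound 2 to compound 3 (0.18 log units; within the scatter), the two being the same compound drawn with and without a configuration (the fact that one of compounds 2 and 3 is drawn with a defined configuration and the other without, at the place where they differ). Compound 1 `CC(C(=O)NCc1ccc(C(F)(F)F)nc1Br)c1ccc(NS(C)(=O)=O)c(F)c1`, with bromo on the aromatic carbon, gives 169 nM, and a 560-fold lower number from compound 1 to compound 3 (2.75 log units; beyond the scatter) shows how much a carbon ring at that position lowers the number. Compound 4 `C[C@H](C(=O)NCc1ccc(C(F)(F)F)nc1C1=CCC(C)(C)CC1)c1ccc(NS(C)(=O)=O)c(F)c1` differs from compound 2 by 4,4-dimethylcyclohex-1-en-1-yl in place of 4-ethylcyclohexyl on an aromatic carbon. Within the data shown here, no measured step exchanges one carbon ring for another; the only step at this position is the bromo-to-ring one. Since compound 4 keeps a ring of the same size there, a step no larger than the scatter is expected, a 1.5-fold higher number from compound 2 to compound 4 (0.18 log units; within the scatter). Compound 4 is estimated at 0.3 nM, within 0.08 nM to 1.5 nM.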

Compound 4, inhibition constant: 0.1 nM
Compound 4: the middle estimate sits 3.0-fold (0.48 log units) above what was measured; measured number inside the range.
By their numbers in this assay, from the lowest: compounds 4, 2 and 3 (each within the scatter of the next, the first and the last beyond it); then compound 1.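

In this assay, exchanging 4-ethylcyclohexyl for 4,4-dimethylcyclohex-1-en-1-yl on this aromatic carbon gives no step beyond the scatter: a 2.0-fold lower number from compound 2 to compound 4 (0.30 log units; within the scatter). The position therefore accepts a second carbon ring of the same size, here with a double bond and two methyl groups in place of one ethyl. Nothing available gives a cause for this step.

On these data alone, whether the double bond or the methyl groups matter on their own remains open, as the saturated 4,4-dimethylcyclohexyl ring does not appear here. Also open, as far as these compounds go, is how a ring carrying an amine, or a phenyl ring, would behave at this position.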